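The source may report more compounds than this note shows. Statements on the series, on what has been measured and on what is new or still open speak of the compounds shown alone.

Compound 1 `COc1ccc(S(=O)(=O)Oc2ccccc2NC(=O)c2ccccn2)cc1`: 300 nM
Compound 2 `COc1ccc(S(=O)(=O)Oc2ccccc2NC(=O)c2ccc(N(C)C)cc2)cc1`: > 10000 nM

Both results come from a functional assay on NCI-H460 cells (Homo sapiens) for antiproliferative activity; a lower number here means a stronger inhibitor, a higher number a weaker inhibitor. For compound 2 the result is only a limit of the assay and not a number: > 10000 nM. Compound 3 `COc1ccc(S(=O)(=O)Oc2ccccc2NC(=O)Oc2ccccc2)cc1` keeps the shared core and carries phenoxy in place of 4-(dimethylamino)phenyl on a carbonyl carbon. Among the measured compounds shown here, one measured step bears on this place: an at least 33-fold higher number from compound 1 to compound 2 (1.52 log units; beyond the scatter), a large step beyond the scatter, made by exchanging pyridin-2-yl for 4-(dimethylamino)phenyl. That step shows that a change here can move the number strongly. Phenoxy itself is untested, so a smaller move toward a lower number in this assay is expected, and compound 3 could still end up at the limit. The expected change is an at least 3.3-fold lower number from compound 2 to compound 3 (0.52 log units; beyond the scatter). For compound 3 the estimated value is 3000 nM, with an expected range of 500 nM to 10000 nM.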

Compound 3, half-maximal inhibitory concentration: > 10000 nM
Compound 3 ended at the assay's limit; the forecaster's own chance of this, stated with the estimate: 35%; middle value at least 3.3-fold (0.52 log units) from the limit.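

In this assay, phenoxy in place of pyridin-2-yl on the carbonyl carbon gives an at least 33-fold higher number from compound 1 to compound 3 (1.52 log units; beyond the scatter), so the loss seen earlier is no longer tied to 4-(dimethylamino)phenyl alone. Of the three groups shown at this place, only pyridin-2-yl gives a value inside the measurable range, and this holds even though the phenoxy group also brings a different link to the carbonyl carbon. Compound 2 and compound 3 cannot be ranked against each other, and the step between them cannot be read, because both stop at the same limit: the limit of > 10000 nM in this assay, at which 2 of the 3 values shown sit.

The compounds shown leave open whether activity depends on pyridin-2-yl specifically or would survive with a plain phenyl or a pyridin-3-yl on the same carbonyl carbon. They also leave open how weak compound 2 and compound 3 really are.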